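Adding a sulfanyl group to compound 2

The compounds below may be only part of what the source reports. "The series", "measured", "known", "first", "only" and "open" are said of these compounds alone.

Compound 1 `O=C(Nc1nc2ccccc2s1)c1ccc(OC(F)F)c(OCC2CC2)c1`: 9.82 h
Compound 2 `O=C(Nc1ccc2ncsc2c1)c1ccc(OC(F)F)c(OCC2CC2)c1`: 22 h

Going by the values given here, in an ADME assay on the whole organism (strain Sprague-Dawley) for metabolic stability, with Rattus norvegicus as the target, read by HPLC, at a dose of 1 mg/kg by the subcutaneous route (on this read-out lower numbers stand for a shorter-lived compound and higher numbers for a longer-lived compound), compound 2 stands highest of the two numbers so far, at 22 h. Compound 3 `O=C(Nc1ccc2nc(S)sc2c1)c1ccc(OC(F)F)c(OCC2CC2)c1` differs from it in one place: sulfanyl in place of hydrogen on an aromatic carbon. Put simply, sulfanyl takes the place of hydrogen on an aromatic carbon, next to the ring nitrogen and next to the ring sulfur.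

Among the compounds with values here, only one measured step bears on this, and only loosely: a 2.2-fold higher number from compound 1 to compound 2 (0.35 log units; beyond the scatter). That modest step puts 1,3-benzothiazol-6-yl in place of 1,3-benzothiazol-2-yl on an amide-type nitrogen, so it adds no new group. Within the data shown here, no measured compound carries sulfanyl, and the data cannot settle a direction. Among the measured compounds shown here, no step beyond the scatter is therefore expected, with a slight lean downward, since compound 2 at 22 h is already the higher of only two numbers. The estimated change is a 1.4-fold lower number from compound 2 to compound 3 (0.14 log units; within the scatter). Compound 3 is expected at 16 h, with an estimated range of 7 h to 35 h.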

Compound 3, half-life: 22 h
Compound 3: the middle estimate sits 1.4-fold (0.14 log units) below what was measured; the measured number falls inside the stated range.
By their numbers in this assay, from the lowest: compound 1; then compounds 2 and 3 (each within the scatter of the next).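

In this assay, putting sulfanyl in place of hydrogen on an aromatic carbon gives no change at the digits printed from compound 2 to compound 3 (within the scatter), so this carbon, next to the ring nitrogen and next to the ring sulfur, can carry the new group with no change in half-life that stands out from the usual scatter. The earlier step, a 2.2-fold higher number from compound 1 to compound 2 (0.35 log units; beyond the scatter), compared two attachment points, 1,3-benzothiazol-6-yl and 1,3-benzothiazol-2-yl, and added no new group, so this pair is the first to isolate the effect of a substituent on this carbon in the shown series. Nothing measured here accounts for the unchanged half-life, and the result stands as an observation without an explanation.

One small group on one carbon cannot show whether this tolerance is general. On these data alone, it remains open whether an amine, a methylsulfanyl group, a carboxylic acid or a longer chain on the same carbon would also leave the half-life where it stands, or would shift it by a step beyond the scatter.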